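The compounds below may be only part of what the source reports. "The series", "measured", "known", "first", "only" and "open" are said of these compounds alone.

Working notes on the series. For the measured compounds named here, in a functional assay on MCF7 cells (Homo sapiens) for antiproliferative activity, read by MTT assay (on this read-out higher numbers stand for weaker inhibition and lower numbers for stronger inhibition), compound 1 (`CCCC/C=C\CCCCCCCCCc1cc(=O)c2c(O)cc(O)c(C)c2o1`) gives 17500 nM as the lower of the two numbers so far. Compound 2 (`CCCC/C=C\CCCCCCCCCC1(O)CC(=O)c2c(O)cc(OCOC)cc2O1`) gives 43200 nM as the higher number, and the gap between the two lies beyond the scatter, so compound 1 currently stands as the stronger inhibitor of the pair. Going by the values given here, no two measured compounds differ in one place only, so the data hold no measured size for a change of chain.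

Compound 3 (`CCCCC/C=C\C/C=C\CCCCCCCc1cc(=O)c2c(O)cc(O)c(C)c2o1`) keeps the core of compound 1 and differs in the chain alone: deca-1,4-dien-1-yl in place of oct-3-en-1-yl on a saturated chain carbon, seven bonds along the chain from an aromatic carbon is the counted difference, with deca-1,4-dien-1-yl in place of oct-3-en-1-yl on a saturated chain carbon, seven bonds along the chain from an aromatic carbon.

Among the compounds with values here, with no measured chain step to draw on, the expectation rests on compound 1 at 17500 nM as its only anchor. The estimated 1.2-fold lower number from compound 1 to compound 3 (0.07 log units; within the scatter) in this assay is expected to stay within the scatter, with no firm direction. For compound 3 the expected value is 15000 nM as a middle, with 7000 nM to 35000 nM as the estimated range.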

Compound 3, half-maximal inhibitory concentration: 17500 nM
Estimate against measurement, compound 3: 1.2-fold (0.07 log units) below; the measured number falls inside the stated range.
By their numbers in this assay, from the lowest: compounds 1 and 3 (each within the scatter of the next); then compound 2.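

In this assay, for the compounds shown here, deca-1,4-dien-1-yl in place of oct-3-en-1-yl on a saturated chain carbon, seven bonds along the chain from an aromatic carbon, gives no change at the digits printed from compound 1 to compound 3 (within the scatter) and is the first measured step. On the core of compound 1, the two chains therefore cannot be told apart at this place, even though the entering chain has 10 heavy atoms against 8 and 2 double bonds outside aromatic rings against 1. This single step does not explain the result, and no supporting evidence bears on it.

The compounds shown leave open whether a fully saturated chain, a much shorter chain, or a chain ending in a carboxylic acid or an amine would also read alike at this place. They also leave open whether the same match between the two chains would hold on the core of compound 2, and whether a step beyond the scatter can be reached by any change to the chain.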